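The source may report more compounds than this note shows. Statements on the series, on what has been measured and on what is new or still open speak of the compounds shown alone.

Compound 1 `COc1cc(C2=NN(C(C)=O)C(c3c(Cl)cccc3Cl)O2)cc(OC)c1OC`: -1.4%
Compound 2 `COc1cc(C2=NN(C(C)=O)C(c3ccc(F)cc3)O2)cc(OC)c1OC`: -0.4%
Compound 3 `COc1cc(C(=O)N/N=C/c2c(Cl)cccc2Cl)cc(OC)c1OC`: 0.9%

In a functional assay on BGC-823 cells (Homo sapiens) for antiproliferative activity, read by MTT assay, tested at 1 uM (on this read-out lower numbers stand for a weaker effect and higher numbers for a stronger effect at the one concentration tested), compound 2 gives -0.4%. Compound 1 gives -1.4% and compound 3 gives 0.9%, and both of these lie within the scatter of the number for compound 2, so the three measured compounds cannot be told apart on this read-out. Going by the values given here, the one step between two measured compounds, a number 1 percentage points higher from compound 1 to compound 2 (within the scatter), is within the scatter as well.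

Compound 4 `COc1cc(C2=NN(C(C)=O)C(c3ccc(F)c(F)c3)O2)cc(OC)c1OC` differs from compound 2 by fluoro in place of hydrogen on an aromatic carbon. Among the compounds with values here, no measured step concerns a fluoro entering in place of hydrogen, so the only guide is the step from compound 1 to compound 2, which was within the scatter despite a larger change on the same ring, and the fact that no measured compound moves away from zero. The step of a number 0.9 percentage points higher from compound 2 to compound 4 (within the scatter) is therefore expected to stay within the scatter. For compound 4 the estimate is 0.5%, with a range from -8% to 9%.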

Compound 4, a percentage reported as inhibition, at one concentration (the size of the read-out at that concentration, not a potency): 18.3%
Compound 4: middle estimate off by 17.8 percentage points, on the low side; measured number outside the range, above it.
By their numbers in this assay, from the lowest: compounds 1, 2 and 3 (each within the scatter of the next); then compound 4.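

In this assay, fluoro in place of hydrogen on an aromatic carbon, ortho to a fluoro group, gives a number 18.7 percentage points higher from compound 2 to compound 4 (beyond the scatter), the first step among these compounds to lie beyond the scatter. The change from 2,6-dichlorophenyl to 3,4-difluorophenyl gives a number 19.7 percentage points higher from compound 1 to compound 4 (beyond the scatter), whereas the change to 4-fluorophenyl gave only a number 1 percentage points higher from compound 1 to compound 2 (within the scatter), so this aromatic carbon is a place where a single added atom can move the read-out. Nothing given here accounts for this step.

Going by these compounds, it remains open whether the step belongs to fluoro itself or would also follow from a methyl, a hydroxyl or an amine on the same carbon. On these data alone, it also remains open whether a fluoro at this carbon would give such a step without the fluoro group ortho to it.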